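A few compounds are considered here, and "the series" means these few. Any claim that something is new, unique, unknown or untested is made for them only; others in the source may bear on it.

Of the compounds shown here, two have been measured so far. Compound 1 `c1cc(-c2cn[nH]c2)c2c(c1)C(c1ncc[nH]1)CC2` gives 14 nM in a functional assay on CHO cells for agonist activity at Alpha-1A adrenergic receptor (Homo sapiens), read by FLIPR and calcium flux (a higher number here means that more compound is needed for the effect, a lower number that less compound is needed), and compound 2 `CCS(=O)(=O)Nc1cccc(Cc2c[nH]cn2)c1` gives 9 nM in this assay. Compound 1 holds the higher of the two numbers, yet its gap to compound 2 lies within the scatter, so the two cannot be set in order.

Compound 3 `c1cc(-c2ncco2)c2c(c1)C(c1ncc[nH]1)CC2` has not yet been measured. It differs from compound 1 in one place: 1,3-oxazol-2-yl in place of 1H-pyrazol-4-yl on an aromatic carbon. Among the measured compounds shown here, no measured pair shows this change, so its effect is unknown from the data. The expectation for compound 3 is therefore a step of a 2.9-fold higher number from compound 1 to compound 3 (0.46 log units; beyond the scatter) of moderate size in this assay, leaning toward a higher number. For compound 3 the expected value in this assay is 40 nM, with a range from 8 nM to 200 nM.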

Compound 3, half-maximal effective concentration: 170 nM
Compound 3: middle estimate off by 4.3-fold (0.63 log units), on the low side, within the range that was stated.
By their numbers in this assay, from the lowest: compounds 2 and 1 (each within the scatter of the next); then compound 3.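

Exchanging one five-membered aromatic ring for another at this aromatic carbon is not a neutral change in this assay: 1,3-oxazol-2-yl in place of 1H-pyrazol-4-yl gives a 12-fold higher number from compound 1 to compound 3 (1.08 log units; beyond the scatter). The two groups match in heavy atoms and ring size, yet 1H-pyrazol-4-yl carries 1 hydrogen-bond donor and 1,3-oxazol-2-yl carries 0, so this position can tell apart groups of the same size. This single pair does not establish why the number rises, and no supporting measurement is available to explain it.

On these data alone, it remains open whether the missing donor matters or something else that differs between the two rings. An amine or a primary amide on this same aromatic carbon could help separate those possibilities, and a plain phenyl ring would show how the core behaves without a ring hetero atom.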